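Carbamate replacement of the geranyl ether in compound 3

The source may report more compounds than this note shows. Statements on the series, on what has been measured and on what is new or still open speak of the compounds shown alone.

Measured so far:
compound 1 `CC(C)=CCC/C(C)=C/COc1cc(=O)n(CCCO)c2c1CC(CC=C(C)C)C(C)(C)C2` 18.4%
compound 2 `CC(C)=CCC1Cc2c(OC(=O)Nc3ccc(F)c(Cl)c3)cc(=O)n(CCCO)c2CC1(C)C` 0%
compound 3 `CC(C)=CCC/C(C)=C/COc1cc(=O)n(CCCO)c2c1CC(C/C=C(\C)CCC=C(C)C)C(C)(C)C2` 3.1%

In a functional assay on PANC-1 cells (Homo sapiens) for inhibition, read by MTT assay, with a stated time of 24 h, tested at 10 uM (a lower number here means less inhibition, a higher number more inhibition at the concentration tested (going by the name of the read-out)), compound 3 gives 3.1%, the second highest of the three numbers, beyond the scatter below compound 1 and within the scatter of compound 2. Compound 4 `CC(C)=CCC/C(C)=C/CC1Cc2c(OC(=O)Nc3ccc(F)c(F)c3)cc(=O)n(CCCO)c2CC1(C)C` differs from compound 3 by (3,4-difluorophenyl)carbamoyl in place of 3,7-dimethylocta-2,6-dien-1-yl on an oxygen on an aromatic ring. Within the data shown here, the one step that bears on this is a number 18.4 percentage points lower from compound 1 to compound 2 (beyond the scatter), the same kind of exchange on the oxygen with a chloro-fluoro instead of a difluoro ring. Compound 3 already stands near the floor of the read-out, so little room remains. Compound 4 is therefore expected to show no step beyond the scatter, a number 2.1 percentage points lower from compound 3 to compound 4 (within the scatter), and an estimated value of 1%, between 0% and 10%.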

Compound 4, a percentage reported as inhibition, at one concentration (the size of the read-out at that concentration, not a potency): 4.8%
Compound 4: the middle estimate sits 3.8 percentage points below what was measured; low and high end bracket the measured number.
By their numbers in this assay, from the lowest: compounds 2, 3 and 4 (each within the scatter of the next); then compound 1.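

In this assay, among these compounds, the (3,4-difluorophenyl)carbamoyl group on the oxygen on an aromatic ring gives a number 1.7 percentage points higher from compound 3 to compound 4 (within the scatter), so with the 3,7-dimethylocta-2,6-dien-1-yl chain kept on the core, this exchange produces no step that can be read. The related carbamoyl exchange gave a number 18.4 percentage points lower from compound 1 to compound 2 (beyond the scatter), so the exchange does not act the same way in both pairs, though compound 3 already stood close to the floor. No available measurement accounts for this result. Still open, from the compounds shown here alone, is whether an amine or a carboxylic acid on the carbamoyl phenyl ring would give a number clear of the floor.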